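Swapping a Ring-Nitrogen Aryl Group for a Benzyl Group

The compounds below may be only part of what the source reports. "The series", "measured", "known", "first", "only" and "open" are said of these compounds alone.

For the measured compounds named here, the three compounds measured so far share one core and were tested in a functional assay on K562 cells (Homo sapiens) for antiproliferative activity, read by MTT assay, with a stated time of 48 h; a lower number here means a stronger inhibitor, a higher number a weaker inhibitor.
Compound 1, `COc1ccc(-c2ccc3c(c2)C(=O)C(=O)N3C)cc1`, gives 4980 nM.
Compound 2, `COc1ccc(-c2ccc3c(c2)C(=O)C(=O)N3c2ccc(OC)cc2)cc1`, gives only > 10000 nM, which is a limit of the assay and not a number.
Compound 3, `COc1ccc(-c2ccc3c(c2)C(=O)C(=O)N3Cc2ccc(Br)cc2)cc1`, gives 100 nM.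

Going by the values given here, compound 2 therefore stands at the weak end of what has been seen: it is the one compound whose value is only (the limit of > 10000 nM in this assay, at which 1 of the 3 values shown sits), so its true number is unknown beyond that boundary. Compound 4, `COc1ccc(-c2ccc3c(c2)C(=O)C(=O)N3Cc2cc(C)cc(C)c2)cc1`, differs from it in one place: 3,5-dimethylbenzyl in place of 4-methoxyphenyl on an amide-type nitrogen in a ring.

Among the compounds with values here, two measured steps bear on this change. The closest is an at least 100-fold lower number from compound 2 to compound 3 (2.00 log units; beyond the scatter), where a benzyl group likewise took the place of the 4-methoxyphenyl group on the ring nitrogen. The step of a 50-fold lower number from compound 1 to compound 3 (1.70 log units; beyond the scatter) points the same way, a benzyl-bearing nitrogen giving the lowest number of the three. Both steps were large and both ran toward a lower number, so a large step toward a lower number in this assay is expected here as well.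

Compound 4 is expected to give about 200 nM, likely between 50 nM and 800 nM, which would mean an estimated step of an at least 50-fold lower number from compound 2 to compound 4 (1.69 log units; beyond the scatter).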

Compound 4, half-maximal inhibitory concentration: 140 nM
For compound 4 the middle estimate is 1.4-fold (0.15 log units) above the measured one, and the stated range covers the measured number.
By their numbers in this assay, from the lowest: compounds 3 and 4 (each within the scatter of the next); then compound 1. At a limit, above all of these: compound 2.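

Compound 2 stands at a limit of the assay and not at a number. In this assay, a second benzyl-type group on the ring nitrogen gives an at least 71-fold lower number from compound 2 to compound 4 (1.85 log units; beyond the scatter), so the large step seen with 4-bromobenzyl is not confined to that one group. The bromine is not needed for a low number either: 3,5-dimethylbenzyl, which has only carbon as its added atoms, gives a 1.4-fold higher number from compound 3 to compound 4 (0.15 log units; within the scatter), and it keeps a large advantage over the methyl group, with a 36-fold lower number from compound 1 to compound 4 (1.55 log units; beyond the scatter).

Both benzyl-type groups shown carry substituents on their rings, so what an unsubstituted benzyl group, a 4-methoxybenzyl group or a longer phenethyl chain would give stays open. A 4-methoxybenzyl group would be especially telling, as it would keep the ring of compound 2 and add only the saturated chain carbon, and a benzyl ring carrying an amine or a carboxylic acid would show whether this position accepts such groups at all.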